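The source may report more compounds than this note shows. Statements on the series, on what has been measured and on what is new or still open speak of the compounds shown alone.

Working notes on the series. Of the compounds shown here, two have been measured in a functional assay on ASPC1 cells (Homo sapiens) for inhibition, read by MTT assay, with a stated time of 72 h; a lower number here means a stronger inhibitor of growth, a higher number a weaker inhibitor of growth. Compound 1 `O=S(=O)(NCCCNCc1ccc(Cl)c(C(F)(F)F)c1)c1cc(C(F)(F)F)cc(C(F)(F)F)c1` gives 9600 nM in this assay, the highest of the two numbers on hand. Compound 2 `O=S(=O)(NCCCNCc1ccc(-c2ccccc2)cc1)c1cc(C(F)(F)F)cc(C(F)(F)F)c1` gives 2500 nM in this assay, a gap from compound 1 that lies beyond the scatter. Going by the values given here, no pair differing in one place has been measured, so no single step is known.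

Compound 3 `COc1cccc(CNCCCNS(=O)(=O)c2cc(C(F)(F)F)cc(C(F)(F)F)c2)c1` is the next point. It differs from compound 1 by 3-methoxyphenyl in place of 4-chloro-3-(trifluoromethyl)phenyl on a saturated chain carbon bound to an amine nitrogen. Among the compounds with values here, no measured pair shows what such a change does in this assay, and compound 2 carries a different group at the same place, so it gives no direct guide.

The step from compound 1 to compound 3 is expected to be small, a 1.1-fold higher number from compound 1 to compound 3 (0.06 log units; within the scatter), likely within the scatter or only modestly toward a higher number. Compound 3 is therefore expected to give about 11000 nM in this assay, in a range from 4000 nM to 30000 nM.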

Compound 3, concentration for 50% growth inhibition: 3800 nM
Estimate against measurement, compound 3: 2.9-fold (0.46 log units) above; the measured number lies below the stated range.
By their numbers in this assay, from the lowest: compounds 2 and 3 (each within the scatter of the next); then compound 1.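

In this assay, going by these compounds alone, the only step read so far at this position, on a saturated chain carbon bound to an amine nitrogen, is a 2.5-fold lower number from compound 1 to compound 3 (0.40 log units; beyond the scatter), with 3-methoxyphenyl in place of 4-chloro-3-(trifluoromethyl)phenyl. This shows that the number responds to the aryl group at this place, and that a group with fewer heavy atoms and one hydrogen-bond acceptor can match the larger group of compound 2, as compound 2 at 2500 nM and compound 3 at 3800 nM lie within the scatter of each other. No measurement on hand accounts for the step.

The step changes chlorine, trifluoromethyl and methoxy together, so the share of each remains unresolved. As far as these compounds go, whether a plain phenyl or a pyridine ring at this place would give a similar number also remains open.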